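Working notes: benzyl for aryl on the aromatic nitrogen

The source may hold more compounds than are shown below. What is called first, only, known or untested is meant among the compounds shown, and "the series" means these compounds.

Measured so far:
compound 1 `CCOC(=O)C1=C(C)N/C(=C/c2cc(C)n(-c3ccc(CN(C)C)cc3)c2C)C1=O`: 120000 nM
compound 2 `CCOC(=O)C1=C(C)N/C(=C/c2cc(C)n(-c3ccc(Cl)cc3)c2C)C1=O`: 100000 nM

In an ADME assay on L6 cells (Rattus norvegicus) for cytotoxicity, read by resazurin assay, with a stated time of 72 h (on this read-out lower numbers stand for an effect already at smaller amounts and higher numbers for an effect only at larger amounts of compound), compound 1 gives 120000 nM, the highest of the two numbers shown, and compound 2 gives 100000 nM; the step of a 1.2-fold lower number from compound 1 to compound 2 (0.08 log units; within the scatter) is within the scatter. Compound 3 `CCOC(=O)C1=C(C)N/C(=C/c2cc(C)n(Cc3ccccc3)c2C)C1=O` is not yet measured. Its difference from compound 1: benzyl in place of 4-((dimethylamino)methyl)phenyl on an aromatic nitrogen. For the measured compounds named here, no measured step changes anything on the aromatic nitrogen, and the one step known, on an aromatic carbon, stayed within the scatter. The step of a 1.1-fold lower number from compound 1 to compound 3 (0.04 log units; within the scatter) is therefore expected to be small. For compound 3 the estimate in this assay is 110000 nM, range 50000 nM to 250000 nM.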

Compound 3, half-maximal effective concentration: 50000 nM
Beside the measured number, compound 3's estimate is 2.2-fold (0.34 log units) above it, and the stated range covers the measured number.
By their numbers in this assay, from the lowest: compounds 3, 2 and 1 (each within the scatter of the next, the first and the last beyond it).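

For the compounds shown here, at the aromatic nitrogen, replacing the aryl group with benzyl gives the first step beyond the scatter in this assay: a 2.4-fold lower number from compound 1 to compound 3 (0.38 log units; beyond the scatter). The same benzyl change made against the 4-chlorophenyl group gives a 2.0-fold lower number from compound 2 to compound 3 (0.30 log units; within the scatter), so the step stays within the scatter, and the effect at this position is clear only against 4-((dimethylamino)methyl)phenyl. No supporting data bear on why this step occurs. Open, as far as these compounds go, is whether a plain phenyl group or a longer chain such as phenethyl on this nitrogen would give a similar number.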